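Working notes: from fluoro to dimethylamino

The source may hold more compounds than are shown below. What is called first, only, known or untested is meant among the compounds shown, and "the series" means these compounds.

- compound 1 `COc1ccc(/C=C2\CCC/C(=C\c3ccccc3[N+](=O)[O-])C2=O)cc1`: 11000 nM
- compound 2 `CN(C)c1ccc(/C=C2\CCC/C(=C\c3cccc([N+](=O)[O-])c3)C2=O)cc1`: 32000 nM
- compound 3 `O=C1/C(=C/c2ccc(F)cc2)CCC/C1=C\c1ccc([N+](=O)[O-])cc1`: 19000 nM

All three values come from a functional assay on HSC-2 cells (Homo sapiens) for cytotoxicity, with a stated time of 24 h; on this read-out lower numbers stand for higher toxicity in this test and higher numbers for lower toxicity in this test. Compound 3, at 19000 nM, is second highest of the three numbers, but it lies within the scatter of both other compounds. Compound 4 `CN(C)c1ccc(/C=C2\CCC/C(=C\c3ccc([N+](=O)[O-])cc3)C2=O)cc1` differs from compound 3 by dimethylamino in place of fluoro on an aromatic carbon, para to a large group. Among the measured compounds shown here, no measured pair isolates this change. Compound 2, which also holds a 4-(dimethylamino)phenyl, gives 32000 nM, so a slightly higher number is expected in this assay, with nothing beyond the scatter. The expected change is a 1.3-fold higher number from compound 3 to compound 4 (0.12 log units; within the scatter). Compound 4 is estimated at 25000 nM, with an expected range of 11000 nM to 55000 nM.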

Compound 4, half-maximal cytotoxic concentration: 11000 nM
Compound 4: the middle estimate sits 2.3-fold (0.36 log units) above what was measured, and the stated range covers the measured number.
By their numbers in this assay, from the lowest: compounds 1, 4, 3 and 2 (each within the scatter of the next, the first and the last beyond it).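

In this assay, dimethylamino in place of fluoro on an aromatic carbon, para to a large group, now has a measured pair and stays within the scatter (a 1.7-fold lower number from compound 3 to compound 4 (0.24 log units; within the scatter)). With the 4-(dimethylamino)phenyl held constant, 4-nitrophenyl in place of 3-nitrophenyl gives a modest step beyond the scatter (a 2.9-fold lower number from compound 2 to compound 4 (0.46 log units; beyond the scatter)), so the nitro placement registers here where the fluoro swap does not. Nothing available explains either step.

Going by these compounds, whether a morpholine or a carboxylic acid at this position would also stay within the scatter remains open. So does whether the nitro step holds with 4-fluorophenyl on the other side.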